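The source may report more compounds than this note shows. Statements on the series, on what has been measured and on what is new or still open speak of the compounds shown alone.

Working notes on the series in an ADME assay on HCT-116 cells (Homo sapiens) for cytotoxicity, read by CellTiter-Glo, with a stated time of 72 h; a lower number here means a stronger inhibitor, a higher number a weaker inhibitor. Compound 3 `COc1ccc(-c2cccc(S(=O)(=O)N3CCC(N4CCC(C)CC4)CC3)c2)cc1` gives > 5000 nM, which is a limit and not a number. Compound 1 `CC1CCN(C2CCN(S(=O)(=O)c3ccc(C#N)cc3)CC2)CC1` gives > 5000 nM, also a limit. Compound 2 `CC1CCN(C2CCN(S(=O)(=O)c3cnc(Cl)s3)CC2)CC1` gives > 10000 nM, again a limit. No value in this small set is therefore a true number, and compound 3 cannot be ranked against the other two.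

Compound 4 `CC1CCN(C2CCN(S(=O)(=O)c3cccc(Cl)c3)CC2)CC1` is the next compound to be read, and the change is chloro in place of 4-methoxyphenyl on an aromatic carbon, so one aromatic ring leaves the structure. Going by the values given here, the only measured step is a step that the two limits leave unreadable from compound 1 to compound 2, a change of the group on a sulfonyl sulfur, and it offers no size to carry over. The expectation for compound 4 rests on compound 3, whose limit is > 5000 nM. The expected change is a step that the limit leaves unreadable from compound 3 to compound 4, with no direction supported by the data. Compound 4 is estimated at 8000 nM, with an expected range from 3000 nM to 20000 nM, and a further limit is the likeliest report.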

Compound 4, half-maximal inhibitory concentration: > 5000 nM
Compound 4 ended at the assay's limit (the forecaster's own chance of this, stated with the estimate: 80%); the middle value does not contradict the limit.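

Compound 4 is a limit, as are compound 1, compound 2 and compound 3, so none of the steps to compound 4 can be read in this assay. The compounds shown leave open whether any group on the sulfonyl sulfur changes the read-out.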